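One more chloro on the benzyl group of compound 2

The source may report more compounds than this note shows. Statements on the series, on what has been measured and on what is new or still open speak of the compounds shown alone.

- Compound 1 `NC(=O)c1c(NC(=O)c2ccccc2Cl)sc2c1CCN(Cc1ccc(Cl)cc1Cl)C2` gives 21100 nM
- Compound 2 `NC(=O)c1c(NC(=O)c2ccc(C(F)(F)F)cc2)sc2c1CCN(Cc1ccc(Cl)cc1)C2` gives > 50000 nM

In a functional assay on HeLa cells (Homo sapiens) for antiproliferative activity, with a stated time of 24 h (on this read-out lower numbers stand for stronger inhibition and higher numbers for weaker inhibition), compound 2 reads > 50000 nM and this is a limit of the assay, not a number. Its true value is therefore unknown, and any step that starts from compound 2 has an uncertain size.

Compound 3 `NC(=O)c1c(NC(=O)c2ccc(C(F)(F)F)cc2)sc2c1CCN(Cc1ccc(Cl)cc1Cl)C2` has the structure of compound 2 with one change (chloro in place of hydrogen on an aromatic carbon) that turns 4-chlorobenzyl into 2,4-dichlorobenzyl. The new chloro takes the place of a hydrogen on an aromatic carbon, ortho to a large group and meta to a chloro group.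

Going by the values given here, no measured pair of compounds shows this change alone. Among the compounds with values here, the only guide is compound 1, which also carries 2,4-dichlorobenzyl and gives 21100 nM in this assay as a real number. A modest move towards stronger inhibition therefore seems likely, though compound 3 may also end up at the limit. The expected size of this move is an at least 1.6-fold lower number from compound 2 to compound 3 (0.22 log units; that floor lies within the scatter) on the estimate made here. For compound 3 the estimated value is 30000 nM with an expected range from 12000 nM to 50000 nM in this assay as the final read-out.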

Compound 3, half-maximal inhibitory concentration: > 50000 nM
Compound 3: a limit, no number (the forecaster's own chance of this, stated with the estimate: 35%); middle value at least 1.6-fold (0.22 log units) from the limit.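

In this assay compound 3 reads > 50000 nM, which is a limit of the assay and not a number. The effect of the new chloro cannot be read because compound 2 and compound 3 both sit at the same limit: the limit of > 50000 nM in this assay, at which 2 of the 3 values shown sit.

Going by these compounds alone, the one readable comparison concerns the other end of the molecule: with 2,4-dichlorobenzyl held constant, 4-(trifluoromethyl)phenyl in place of 2-chlorophenyl on the carbonyl carbon gives an at least 2.3-fold higher number from compound 1 to compound 3 (0.37 log units; beyond the scatter), so 2,4-dichlorobenzyl alone does not ensure a value that can be read in this assay.

Going by these compounds, it remains open whether the same chloro would change the read-out when the carbonyl carries 2-chlorophenyl, where a real number is available, and whether a fluoro, a methyl or a methoxy group in its place would behave any differently. On these data alone, it is also open whether an amine or a carboxylic acid on the benzyl group would bring compounds carrying 4-(trifluoromethyl)phenyl to a value that can be read as a number.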